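This account rests on a few compounds, and the source may have more. Where it says the series, first, only, none or still open, it means among the compounds named here.

Three compounds share one core and differ only in the group attached to the carbonyl carbon of the acyl amine. Compound 1 `COc1cc(C(N)=O)cc2nc(NC(=O)c3nccc4ccccc34)n(CCCNC(=O)OCc3ccccc3)c12` carries an isoquinolin-1-yl group there, compound 2 `COc1cc(C(N)=O)cc2nc(NC(=O)c3cccnn3)n(CCCNC(=O)OCc3ccccc3)c12` a pyridazin-3-yl group, and compound 3 `COc1cc(C(N)=O)cc2nc(NC(=O)c3ccnn3C)n(CCCNC(=O)OCc3ccccc3)c12` a 1-methyl-1H-pyrazol-5-yl group. In an assay for activation of interferon regulatory factor 3 (Homo sapiens), read by a luciferase reporter, with a stated time of 20 h (on this read-out lower numbers stand for an effect already at smaller amounts and higher numbers for an effect only at larger amounts of compound), compound 1 gives > 100000 nM, which is a limit of the assay rather than a number. In this assay compound 2 likewise gives only a limit, > 100000 nM. Compound 3 also stands at a limit in this assay, > 100000 nM. Because all three values sit at the limit of > 100000 nM in this assay, at which 3 of the 3 values shown sit, the three steps cannot be read: a step that the two limits leave unreadable from compound 1 to compound 2, a step that the two limits leave unreadable from compound 1 to compound 3 and a step that the two limits leave unreadable from compound 2 to compound 3. Compound 4 `COc1cc(C(N)=O)cc2nc(NC(=O)C3CCCN3C)n(CCCNC(=O)OCc3ccccc3)c12` is not yet measured in this assay; its change from compound 3 is 1-methylpyrrolidin-2-yl in place of 1-methyl-1H-pyrazol-5-yl on a carbonyl carbon. Going by the values given here, no measured step bears on this change, as none could be read. It is expected that compound 4 will again show only a limit, with an expected step of a number no higher from compound 3 to compound 4 (the limit leaves the size open). The estimate for compound 4 is 100000 nM, expected to lie between 30000 nM and 300000 nM.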

Compound 4, half-maximal effective concentration: > 100000 nM
Compound 4 gave a limit, no number (the forecaster's own chance of this, stated with the estimate: 85%); the middle value sits exactly at the limit.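

Going by these compounds alone, compound 4 also stands only at a limit in this assay, so no step between it and compound 1, compound 2 or compound 3 can be read, as all four share one limit: the limit of > 100000 nM in this assay, at which 4 of the 4 values shown sit. The compounds shown leave open whether any group on the carbonyl carbon gives a measurable value.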